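The source may report more compounds than this note shows. Statements on the series, on what has been measured and on what is new or still open speak of the compounds shown alone.

Compound 3 `CSC[C@H](NC(=O)c1ccc(C#Cc2ccccc2)cc1)C(=O)NO` gives 2000 nM in a physicochemical assay for solubility (a higher number here means a more soluble compound, a lower number a less soluble compound), the lowest of the three numbers: compound 1 `O=C(N[C@@H](CO)C(=O)NO)c1ccc(C#Cc2ccccc2)cc1` gives 28000 nM and compound 2 `COCCNC(=O)C[C@H](NC(=O)c1ccc(C#Cc2ccccc2)cc1)C(=O)NO` gives 78000 nM. The change from compound 3 to compound 4 `O=C(C[C@H](NC(=O)c1ccc(C#Cc2ccccc2)cc1)C(=O)NO)NCCCO` is (3-hydroxypropyl)carbamoyl in place of methylsulfanyl on a saturated chain carbon, two bonds along the chain from an amide-type nitrogen and a carbonyl carbon. Among the compounds with values here, two measured steps bear on it, each replacing hydroxy or (2-methoxyethyl)carbamoyl at this place with methylsulfanyl: a 14-fold lower number from compound 1 to compound 3 (1.15 log units; beyond the scatter) and a 39-fold lower number from compound 2 to compound 3 (1.59 log units; beyond the scatter). Read in the opposite direction, both point to a large rise in this assay. Compound 2 carries a carbamoyl chain at the same place, and compound 4 is expected to land near it. Compound 4 is therefore expected to show a step of a 35-fold higher number from compound 3 to compound 4 (1.54 log units; beyond the scatter). Compound 4 is estimated at 70000 nM, within 30000 nM to 160000 nM.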

Compound 4, solubility: 82000 nM
For compound 4 the middle estimate is 1.2-fold (0.07 log units) below the measured one; the measured number falls inside the stated range.
By their numbers in this assay, from the lowest: compound 3; then compound 1; then compounds 2 and 4 (each within the scatter of the next).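

In this assay, the end of the carbamoyl chain carries little weight at this place: hydroxymethyl in place of methoxy gives a 1.1-fold higher number from compound 2 to compound 4 (0.02 log units; within the scatter). A second carbamoyl chain gives a 41-fold higher number from compound 3 to compound 4 (1.61 log units; beyond the scatter) and a 2.9-fold higher number from compound 1 to compound 4 (0.47 log units; beyond the scatter), so these steps are not tied to the chain of compound 2 alone. No measurement in hand accounts for these differences.

Open, from the compounds shown here alone, is whether a carboxylic acid or an amine on this saturated chain carbon would reach the same range in this assay. Also open, going by these compounds, is whether a plain unsubstituted carbamoyl or a longer chain on the amide nitrogen would do so.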